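Removing the methoxy from the core of compound 2

This account rests on a few compounds, and the source may have more. Where it says the series, first, only, none or still open, it means among the compounds named here.

Compound 2 `COC(=O)c1sc2cc(OC)ccc2c1C#Cc1ccccc1` is the reference point. Within the data shown here, in a functional assay on cells (CNS cell, Homo sapiens) for cytotoxicity, read by sulforhodamine B assay, with a stated time of 48 h (on this read-out higher numbers stand for weaker inhibition of growth and lower numbers for stronger inhibition of growth), compound 2 gives 42300 nM, the second highest of the three numbers measured so far. Compound 1 `COC(=O)c1sc2ccccc2c1C#Cc1ccc(OC)cc1` gives 103000 nM in this assay, and compound 3 `COC(=O)c1sc2cc(OC)ccc2c1C#Cc1ccccc1F` gives 10300 nM. Among the measured compounds shown here, the only single-point step measured runs a 4.1-fold lower number from compound 2 to compound 3 (0.61 log units; beyond the scatter). Compound 4 `COC(=O)c1sc2ccccc2c1C#Cc1ccccc1` differs from compound 2 by hydrogen in place of methoxy on an aromatic carbon. For the measured compounds named here, no measured step bears directly on this change: the step from compound 2 to compound 3 concerns fluoro in place of hydrogen on an aromatic carbon, a different change, and compound 1 and compound 2 differ at two places, so their two values show only that compound 1 sits at a higher number than compound 2 without isolating the methoxy on the core. Going by the values given here, with no measured counterpart for this change, no step beyond the scatter is expected in this assay, and the estimate for compound 4 is 42000 nM, with a range of 15000 nM to 120000 nM, which means an expected step of a 1.0-fold lower number from compound 2 to compound 4 (0.00 log units; within the scatter).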

Compound 4, concentration for 50% growth inhibition: 58900 nM
For compound 4 the middle estimate is 1.4-fold (0.15 log units) below the measured one; the measured number falls inside the stated range.
By their numbers in this assay, from the lowest: compound 3; then compounds 2, 4 and 1 (each within the scatter of the next, the first and the last beyond it).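

In this assay the step of a 1.4-fold higher number from compound 2 to compound 4 (0.14 log units; within the scatter) lies within the scatter, so at this aromatic carbon of the shared core, hydrogen and methoxy cannot be told apart. The methoxy of compound 1, which stands at a different place, reads the same way: the step of a 1.7-fold lower number from compound 1 to compound 4 (0.24 log units; within the scatter) also lies within the scatter, so neither single methoxy shifts the number beyond the scatter, with compound 4 as the shared comparison. Nothing available bears on why these changes leave the number within the scatter.

Open, going by these compounds, is whether an amine or a carboxylic acid on this aromatic carbon would stay within the scatter as hydrogen and methoxy do. Also open, on these data alone, is whether the step of a 4.1-fold lower number from compound 2 to compound 3 (0.61 log units; beyond the scatter) would recur on the core of compound 4 without the methoxy.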